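The source may report more compounds than this note shows. Statements on the series, on what has been measured and on what is new or still open speak of the compounds shown alone.

Measured compounds: compound 1 `COc1cc(Oc2ccc(NC(=O)Nc3cccc(C(F)(F)F)c3)cc2)ncn1` gives 4000 nM; compound 2 `CNc1cc(Oc2ccc(NC(=O)Nc3cccc(C(C)(F)F)c3)cc2)ncn1` gives 40 nM; compound 3 `CNc1cc(Oc2ccc(NC(=O)Nc3cccc(CF)c3)cc2)ncn1` gives 400 nM.

In an assay on isolated protein for inhibition of serine/threonine-protein kinase TNNI3K (Homo sapiens) (on this read-out higher numbers stand for weaker inhibition and lower numbers for stronger inhibition), compound 1 stands highest of the three, with compound 3 nearest and compound 2 furthest. Compound 4 `CC(=O)Nc1cc(Oc2ccc(NC(=O)Nc3cccc(C(F)(F)F)c3)cc2)ncn1` differs from compound 1 by a single change: acetamido in place of methoxy on an aromatic carbon. Among the compounds with values here, the only measured step with one change, a 10-fold higher number from compound 2 to compound 3 (1.00 log units; beyond the scatter), concerns a different part of the molecule and does not touch the pyrimidine substituent. Compounds 1 and 2 differ in two places at once, so their values cannot be tied to this one change. With no direct guide, a moderate step toward stronger inhibition is expected for compound 4, meaning a 4.0-fold lower number from compound 1 to compound 4 (0.60 log units; beyond the scatter). Compound 4 is therefore estimated at 1000 nM, within 200 nM to 5000 nM.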

Compound 4, half-maximal inhibitory concentration: 20 nM
Compound 4: the middle estimate sits 50-fold (1.70 log units) above what was measured; the measured number lies below the stated range.
By their numbers in this assay, from the lowest: compounds 4 and 2 (each within the scatter of the next); then compound 3; then compound 1.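

In this assay, acetamido in place of methoxy on this aromatic carbon gives a 200-fold lower number from compound 1 to compound 4 (2.30 log units; beyond the scatter), so this one position alone can move the read-out by a large step. The trifluoromethyl group stays in place across this pair, which ties the step to the swap at this carbon. Nothing available explains the step.

Which part of acetamido matters, the amide hydrogen or the carbonyl, stays open. A longer chain such as propanamido, or a plain amino group at this carbon, would help to tell how much the change depends on each part.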